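Amide substituent on the enone core: dichlorophenyl replaces propyl

The source may hold more compounds than are shown below. What is called first, only, known or untested is meant among the compounds shown, and "the series" means these compounds.

Compound 3 `CCCC(=O)Nc1cccc(C(=O)/C=C/c2ccc(O)c(OC)c2)c1` stands highest of the three numbers: in a functional assay on HUVEC cells (Homo sapiens) for inhibition, tested at 10 ug/mL (a lower number here means a weaker effect, a higher number a stronger effect of the compound at the concentration tested), compound 3 gives 87%. Compound 1 `COc1cc(/C=C/C(=O)c2cccc(NC(=O)c3cc(Cl)cc(Cl)c3)c2)ccc1O` gives 58%, and compound 2 `COC(=O)C(=O)Nc1cccc(C(=O)/C=C/c2ccc(O)c(OC)c2)c1` gives 43%. The step to compound 4 `COc1cc(/C=C/C(=O)c2cccc(NC(=O)c3c(Cl)cccc3Cl)c2)ccc1O` is 2,6-dichlorophenyl in place of propyl on a carbonyl carbon. The measured steps that bear on it run in the opposite direction: a number 29 percentage points higher from compound 1 to compound 3 (beyond the scatter), and the larger a number 44 percentage points higher from compound 2 to compound 3 (beyond the scatter). A dichlorophenyl group on this carbonyl carbon has so far read lower than propyl, so a drop beyond the scatter is expected on moving from compound 3 to compound 4, roughly a number 32 percentage points lower from compound 3 to compound 4 (beyond the scatter). The estimate for compound 4 in this assay is therefore 55%, within 35% to 75%.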

Compound 4, a percentage reported as inhibition, at one concentration (the size of the read-out at that concentration, not a potency): 99%
Compound 4: the middle estimate sits 44 percentage points below what was measured; the measured number lies above the stated range.
By their numbers in this assay, from the lowest: compound 2; then compound 1; then compound 3; then compound 4.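

In the series read through this assay, a dichlorophenyl group on this carbonyl carbon does not have to read below propyl: 2,6-dichlorophenyl in place of propyl gives a modest rise (a number 12 percentage points higher from compound 3 to compound 4 (beyond the scatter)). The earlier low reading belongs to 3,5-dichlorophenyl and not to dichlorophenyl as such, as the large gain on moving the chlorines shows (a number 41 percentage points higher from compound 1 to compound 4 (beyond the scatter)). The gain over the methoxycarbonyl compound is larger still (a number 56 percentage points higher from compound 2 to compound 4 (beyond the scatter)). Nothing at hand explains these differences. Still open, on these data alone, is how plain phenyl, a single-chlorine phenyl or a longer alkyl chain would read on this carbonyl carbon.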